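This account rests on a few compounds, and the source may have more. Where it says the series, first, only, none or still open, it means among the compounds named here.

Measured compounds and their values:
- compound 1, `O=[N+]([O-])c1cccc(CNc2cc(C(F)(F)F)cc3[nH]ncc23)c1`, 60%
- compound 2, `COc1cc(CNc2cc(Br)cc3[nH]ncc23)c([N+](=O)[O-])cc1OC`, 87%
- compound 3, `FC(F)(F)c1cccc(CNc2cc(C(F)(F)F)cc3[nH]ncc23)c1`, 40%

In an assay for inhibition of Tryptophan 2,3-dioxygenase (Homo sapiens), with stated times of 10 min and 60 min, tested at 10 uM (on this read-out lower numbers stand for a weaker effect and higher numbers for a stronger effect at the one concentration tested), compound 3 stands lowest of the three numbers. Its nearest neighbour is compound 1, which lies higher by a step beyond the scatter, and compound 2 lies furthest above it, also beyond the scatter. Going by the values given here, the one measured step that starts from a single change is a number 20 percentage points lower from compound 1 to compound 3 (beyond the scatter), a modest drop when trifluoromethyl replaces nitro on the aromatic carbon of the pendant ring.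

Compound 4, `O=C(O)c1cccc(CNc2cc(C(F)(F)F)cc3[nH]ncc23)c1`, differs from compound 3 in the following way: carboxy in place of trifluoromethyl on an aromatic carbon. This step bears a loose relation to the measured one, since it again exchanges trifluoromethyl for a group of a different kind at the same place; the earlier step showed that such an exchange moved this assay by a modest amount. Among the compounds with values here, no measured compound carries carboxy, so the direction is uncertain, and the expectation rests on the size of that one step rather than on its sign.

Compound 4 is therefore expected to change by a number 5 percentage points higher from compound 3 to compound 4 (within the scatter), a small shift that may or may not exceed the scatter. The estimate for compound 4 is 45%, within a range of 20% to 70%.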

Compound 4, a percentage reported as inhibition, at one concentration (the size of the read-out at that concentration, not a potency): 81%
Compound 4: middle estimate off by 36 percentage points, on the low side; measured number above the stated range.
By their numbers in this assay, from the lowest: compound 3; then compound 1; then compounds 4 and 2 (each within the scatter of the next).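

In this assay, the group on this aromatic carbon, meta to a large group, can move the read-out either way from nitro: trifluoromethyl gives a number 20 percentage points lower from compound 1 to compound 3 (beyond the scatter), whereas carboxy gives a number 21 percentage points higher from compound 1 to compound 4 (beyond the scatter), so the earlier drop did not mark a limit on what this place accepts. Measured against trifluoromethyl, carboxy gives a number 41 percentage points higher from compound 3 to compound 4 (beyond the scatter), a large step and the widest seen among these three compounds, which differ only at this one place. Carboxy carries a hydrogen-bond donor and a hydrogen-bond acceptor that trifluoromethyl lacks, but nothing available here links that count or any other feature of the group to the rise.

The compounds shown leave open whether the free carboxylic acid is itself needed, since neither a methyl ester nor a primary carboxamide appears at this place, and neither does a tetrazole. They also leave open whether carboxy would give a similar step with bromine on the shared core in place of trifluoromethyl, or on another carbon of the same ring, and whether these stronger and weaker effects at the one concentration tested would hold at any other concentration.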